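The compounds below may be only part of what the source reports. "The series", "measured", "known", "first", "only" and "open" are said of these compounds alone.

Measured so far:
compound 1, `C[C@@H](c1cc2cccnc2cc1F)n1cnc2ncc(-c3cnn(C)c3)nc21`, 8 uL/min
compound 2, `CC(c1ccc2ncc(-c3ccc(F)cc3)cc2c1)n1nnc2ncc(-c3ccncc3)nc21`, 14 uL/min

In an ADME assay on microsomes from liver (Homo sapiens) for metabolic stability, read by LC-MS, using NADPH, with stated times of 5 min and 30 min, tested at 1 uM (a higher number here means faster removal of the compound, a lower number slower removal), compound 1 gives 8 uL/min and compound 2 gives 14 uL/min. These two numbers lie within the scatter of each other, so compound 2 does not stand apart from compound 1 in this assay; neither can be called faster or slower cleared on what is shown.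

Compound 3, `CC(c1ccc2ncc(-c3cnn(C)c3)cc2c1)n1nnc2ncc(-c3ccncc3)nc21`, is not yet measured. It differs from compound 2 in one place: 1-methyl-1H-pyrazol-4-yl in place of 4-fluorophenyl on an aromatic carbon. Going by the values given here, no step between measured compounds touches that position, so the size of the step can only be guessed from the two numbers at hand, both of which carry a 1-methyl-1H-pyrazol-4-yl group somewhere in the molecule and both of which sit close together in this assay.

The step from compound 2 to compound 3 is therefore expected to be small, a 1.4-fold lower number from compound 2 to compound 3 (0.15 log units; within the scatter), leaning toward a lower number but not clearly beyond the scatter. For compound 3 in this assay the estimate is 10 uL/min, with a range from 5 uL/min to 20 uL/min.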

Compound 3, intrinsic clearance in a liver preparation (reported as CLH), per the amount of preparation that the assay uses: 22 uL/min
The estimate for compound 3 lay 2.2-fold (0.34 log units) below the measured number; the measured number lies above the stated range.
By their numbers in this assay, from the lowest: compounds 1, 2 and 3 (each within the scatter of the next, the first and the last beyond it).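

In this assay, going by these compounds alone, putting 1-methyl-1H-pyrazol-4-yl in place of 4-fluorophenyl on an aromatic carbon of the six-membered aromatic ring with 1 nitrogen gives a 1.6-fold higher number from compound 2 to compound 3 (0.20 log units; within the scatter), which is the first step that can be read at this position. The exchange replaces a six-membered aromatic ring of carbon only, with 0 hydrogen-bond acceptors, by a five-membered aromatic ring with 2 hetero atoms and 2 hydrogen-bond acceptors, yet this read-out does not separate the two groups. Nothing available on this pair accounts for the size of the step.

Going by these compounds, both groups seen at this position are aromatic rings, so it remains open how a group of a different kind, such as an amine, a carboxylic acid or a short alkyl chain, would read in this assay when placed on the same aromatic carbon. Also open, on these data alone, is whether the same exchange would give a step of similar size with the rest of the molecule altered, as a single pair at a single position cannot show this.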